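The source may hold more compounds than are shown below. What is called first, only, known or untested is meant among the compounds shown, and "the series" means these compounds.

In an assay on HeLa cells for inhibition of sphingosine-1-phosphate transporter SPNS2 (Mus musculus), read by LC-MS, tested at 2 uM (a lower number here means less inhibition, a higher number more inhibition at the concentration tested (going by the name of the read-out)), the three measured compounds stand as follows:

compound 1, `CCCCCCCCCCc1ccc(-c2noc(C3CCNCC3)n2)cc1`, gives 66%
compound 2, `CCCCCCCCCCc1ccc(-c2noc([C@@H]3CC[C@H](N)C3)n2)cc1`, gives 38%
compound 3, `CCCCCCCCCCc1ccc(-c2noc(CC(O)CN)n2)cc1`, gives 59%

Compound 2 holds the lowest of the three numbers; its nearest neighbour is compound 3 and its furthest is compound 1, both beyond the scatter. Between compound 1 and compound 2 the change is a number 28 percentage points lower from compound 1 to compound 2 (beyond the scatter), and between compound 2 and compound 3 it is a number 21 percentage points higher from compound 2 to compound 3 (beyond the scatter). Compound 1 and compound 3 sit within the scatter of one another, a number 7 percentage points lower from compound 1 to compound 3 (within the scatter).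

Compound 4, `CCCCCCCCCCc1ccc(-c2noc(CCCN3CCCC3)n2)cc1`, is not yet measured. It differs from compound 2 as follows: 3-(pyrrolidin-1-yl)propyl in place of 3-aminocyclopentyl on an aromatic carbon

Both steps that leave compound 2 for another amine-bearing group, to compound 1 and to compound 3, ran upward by a modest amount. Among the measured compounds shown here, no measured compound carries a group with a ring of the kind entering here, so its own effect is unknown. On the two modest upward steps away from the 3-aminocyclopentyl group, compound 4 is expected to move upward in this assay by a number 14 percentage points higher from compound 2 to compound 4 (beyond the scatter), with wide uncertainty. The estimate for compound 4 in this assay is 52%, expected to lie between 25% and 75%.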

Compound 4, a percentage reported as inhibition, at one concentration (the size of the read-out at that concentration, not a potency): 3%
Compound 4: middle estimate off by 49 percentage points, on the high side; measured number outside the range, below it.
By their numbers in this assay, from the lowest: compound 4; then compound 2; then compounds 3 and 1 (each within the scatter of the next).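

In this assay, this position on the five-membered aromatic ring with 2 nitrogen and 1 oxygen does not accept every amine-bearing group equally: the move to 3-(pyrrolidin-1-yl)propyl gives a number 35 percentage points lower from compound 2 to compound 4 (beyond the scatter), a large step where the earlier changes were modest or within the scatter. The same group also stands well under the other two compounds, with a number 56 percentage points lower from compound 3 to compound 4 (beyond the scatter) and a number 63 percentage points lower from compound 1 to compound 4 (beyond the scatter), so compound 4 is the lowest of the four, with every step to it beyond the scatter. Carrying a nitrogen in the group is therefore not enough on its own to keep the read-out in the range of compound 1 and compound 3, and the three steps to compound 4 show how far it can fall. No data at hand explain this drop.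

The change from compound 2 alters several things at once, including the ring, the chain and the count of hydrogen-bond donors, from 1 to 0, so these features cannot be separated here. Open, as far as these compounds go, is whether 3-aminopropyl or 3-(dimethylamino)propyl at this position would stay near compound 4 or return towards compound 1, which would show whether the propyl chain or the substituted nitrogen goes with the loss.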